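Shortening the chain of compound 1

A few compounds are considered here, and "the series" means these few. Any claim that something is new, unique, unknown or untested is made for them only; others in the source may bear on it.

In a functional assay on PLC-PRF-5 cells (Homo sapiens) for inhibition, read by MTT assay, with a stated time of 72 h (on this read-out lower numbers stand for stronger inhibition and higher numbers for weaker inhibition), compound 1 (`Nc1nc2cc(-c3nn(CCCCCCCCCC(=O)NO)c4ncnc(N)c34)ccc2o1`) stands at > 100000 nM which is a limit of the assay, not a number. Compound 4 (`Nc1nc2cc(-c3nn(CCCCC(=O)NO)c4ncnc(N)c34)ccc2o1`) carries hydroxycarbamoyl in place of 5-(hydroxycarbamoyl)pentyl on a saturated chain carbon, four bonds along the chain from an aromatic nitrogen. The closest evidence comes from a different aromatic group, where compound 2 (`Nc1ncnc2c1c(-c1cnc3[nH]ccc3c1)nn2CCCCCCCCCC(=O)NO`) gives 34200 nM in this assay after a change that left the chain alone (an at least 2.9-fold lower number from compound 1 to compound 2 (0.46 log units; beyond the scatter)). Among the measured compounds shown here, compound 3 (`Nc1ncnc2c1c(-c1cnc3[nH]ccc3c1)nn2CCCCCCC(=O)NO`) has a shorter chain and stands at the limit > 50000 nM in this assay as its only reading. That shortening showed no gain (an at least 1.4-fold higher number from compound 2 to compound 3 (0.16 log units; that floor lies within the scatter)). No step beyond the scatter is therefore expected in this assay and the estimated step is small (a number no higher from compound 1 to compound 4 (the limit leaves the size open)). For compound 4 the expected value is 100000 nM within an estimated range of 30000 nM to 300000 nM and a limit reading is likely.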

Compound 4, half-maximal inhibitory concentration: 29600 nM
For compound 4 the middle estimate is 3.4-fold (0.53 log units) above the measured one; measured number below the stated range.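

On the core of compound 1, removing part of the chain moved the reading in this assay in the direction of stronger inhibition (an at least 3.3-fold lower number from compound 1 to compound 4 (0.52 log units; beyond the scatter)). The shortening from compound 2 to compound 3 had shown no such gain, so the effect of chain length at this position differs between these two pairs. Going by these compounds, the true size of the step stays open because compound 1 gives no number: the limit of > 100000 nM in this assay, at which 1 of the 4 values shown sits.

On these data alone, whether a still shorter chain would go further remains open, as does the effect of a carboxylic acid in place of hydroxycarbamoyl.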